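The source may hold more compounds than are shown below. What is called first, only, known or untested is meant among the compounds shown, and "the series" means these compounds.

In a physicochemical assay for solubility, read by spectrophotometry, in phosphate buffer, with a stated time of 18 h, at pH 7.4 (on this read-out higher numbers stand for higher solubility and lower numbers for lower solubility), compound 1, `C#Cc1ccccc1-c1c(C#N)c(-c2ccc(CC)cc2)nc2c1c(C)nn2-c1ccccc1`, gives 46000 nM. Compound 2, `Cc1cccc(-c2nc3c(c(C)nn3-c3ccccc3)c(-c3ccccc3O)c2C#N)c1`, gives 42000 nM in this assay, the lower of the two numbers, though its nearest neighbour, compound 1, sits within the usual scatter of it, so no order between the two can be read from these values. Compound 3, `Cc1nn(-c2ccccc2)c2nc(-c3ccc(I)cc3)c(C#N)c(-c3ccccc3O)c12`, differs from compound 2 in one place: 4-iodophenyl in place of 3-methylphenyl on an aromatic carbon. Within the data shown here, no measured pair in this set shares that change, so its effect on this assay cannot be taken from a known step, and the two values at hand give only a starting level. The change is expected to lower the number somewhat, by a step of a 2.3-fold lower number from compound 2 to compound 3 (0.37 log units; beyond the scatter) that lies beyond the scatter but is not large. Compound 3 is therefore estimated at 18000 nM in this assay, with a range from 6000 nM to 45000 nM.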

Compound 3, solubility: 1500 nM
Beside the measured number, compound 3's estimate is 12-fold (1.08 log units) above it, and the stated range ends above it.
By their numbers in this assay, from the lowest: compound 3; then compounds 2 and 1 (each within the scatter of the next).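

Putting 4-iodophenyl in place of 3-methylphenyl gives a 28-fold lower number from compound 2 to compound 3 (1.45 log units; beyond the scatter) in this assay, a large step. Among these compounds, this shows that the read-out is sensitive to the group on this aromatic carbon, next to the ring nitrogen and ortho to a cyano group, even though the earlier compounds sat within the scatter of each other. The two groups have the same counts of heavy atoms, hydrogen-bond donors and acceptors and neither carries a net charge, so those counts do not separate them, and nothing at hand says what lies behind the step.

The change swaps methyl for iodine and also moves the substituent on the phenyl ring, and only 4-methylphenyl or 3-iodophenyl at this place could tell those two changes apart. From the compounds shown here alone, it also remains open how a phenyl carrying an amine or a carboxylic acid would read here.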